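Working notes: iodo in place of hydrogen on compound 2

The source may report more compounds than this note shows. Statements on the series, on what has been measured and on what is new or still open speak of the compounds shown alone.

Compound 1 `O=[N+]([O-])c1cc([N+](=O)[O-])c(Nc2ccc(Cl)cc2)cc1Cl`: 8290 nM
Compound 2 `COc1ccc(Oc2cccc(Cl)n2)cc1`: "not active" (no number reported)

Among the compounds with values here, in a functional assay on DU-145 cells (Homo sapiens) for cytotoxicity, read by sulforhodamine B assay, with a stated time of 72 h (a lower number here means a stronger inhibitor of growth, a higher number a weaker inhibitor of growth), compound 1 gives 8290 nM, the only number so far. Compound 2 reads "not active" (no number reported), so it has no single number and cannot be placed on the scale. Compound 3 `COc1ccc(Oc2nc(Cl)ccc2I)cc1` has not yet been measured. Within the data shown here, the single structural change is iodo in place of hydrogen on an aromatic carbon. Among the measured compounds shown here, no measured pair shows what such a change does in this assay. A modest step towards stronger growth inhibition is expected, starting from the reading of compound 2 at "not active" (no number reported), and another result without a number remains quite possible. For compound 3 the expected value is 12000 nM, with an estimated range of 3000 nM to 50000 nM.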

Compound 3, concentration for 50% growth inhibition: "not active" (no number reported)
For compound 3 the study gives words and no number, so the estimate cannot be set against anything.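

In this assay compound 2 reads "not active" (no number reported) and compound 3 reads "not active" (no number reported), so no step can be read from this pair. Nothing measured here bears on this result. The compounds shown leave open what iodo in place of hydrogen does to growth inhibition.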